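The compounds below may be only part of what the source reports. "The series", "measured", "known", "first", "only" and "open" are said of these compounds alone.

Measured in a functional assay on Huh-7 cells (Homo sapiens) for antiproliferative activity, with a stated time of 48 h; on this read-out lower numbers stand for stronger inhibition and higher numbers for weaker inhibition:
- compound 1 `CCN(CC)c1ccc(-c2ccc(C#N)cc2)nn1`: > 25000 nM (a limit, not a number)
- compound 2 `CCN(CC)c1ccc(-c2ccc(C(C)=O)cc2)nn1`: 25000 nM
- compound 3 `CCN(CC)c1ccc(-c2ccc(C(=O)O)cc2)nn1`: > 25000 nM (a limit, not a number)

Compound 3 has no number in this assay and stands only at the limit > 25000 nM. The same holds across the series: the limit of > 25000 nM in this assay, at which 2 of the 3 values shown sit.

Compound 4 `CCOC(=O)c1ccc(-c2ccc(N(CC)CC)nn2)cc1` differs from compound 3 by ethyl in place of hydrogen on an oxygen next to a carbonyl group. Ethyl replaces hydrogen on an oxygen next to a carbonyl group, so carboxy becomes ethoxycarbonyl.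

Among the measured compounds shown here, the steps that bear on this change are a number no lower from compound 2 to compound 3 (the limit leaves the size open) and a step that the two limits leave unreadable from compound 1 to compound 3, with a number no higher from compound 1 to compound 2 (the limit leaves the size open) as the third. None of them has a readable size, so the series offers no measured size to carry over, and no step beyond the scatter is expected in either direction.

For the measured compounds named here, compound 2, at 25000 nM, holds the only number and anchors the expectation. The expected step is an at least 1.2-fold lower number from compound 3 to compound 4 (0.09 log units; that floor lies within the scatter). Compound 4 is estimated at 20000 nM, with an expected range of 7000 nM to 40000 nM.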

Compound 4, half-maximal inhibitory concentration: 9000 nM
The estimate for compound 4 lay 2.2-fold (0.35 log units) above the measured number, and the stated range covers the measured number.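

Of the groups shown on this aromatic carbon, ethoxycarbonyl gives the most potent compound in this assay: a 2.8-fold lower number from compound 2 to compound 4 (0.44 log units; beyond the scatter). Against the carboxy and cyano compounds there are only floors, an at least 2.7-fold lower number from compound 3 to compound 4 (0.44 log units; beyond the scatter) and an at least 2.7-fold lower number from compound 1 to compound 4 (0.44 log units; beyond the scatter). This is the first readable size in the series, as the earlier steps cannot be read because of the assay limit: the limit of > 25000 nM in this assay, at which 2 of the 4 values shown sit.

On these data alone, whether the step depends on the ethyl chain or on the ester as a whole stays open, and methoxycarbonyl, a longer chain on the oxygen or a primary amide at this carbon would separate the two. The rest of the molecule is the same in all four compounds, so nothing here shows whether the step carries over to another core.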